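The source may report more compounds than this note shows. Statements on the series, on what has been measured and on what is new or still open speak of the compounds shown alone.

Measured so far in an assay on isolated protein for inhibition of advanced glycosylation end product-specific receptor (Homo sapiens), read by FRET, with stated times of 30 min and 1 h, tested at 4 uM; on this read-out higher numbers stand for more inhibition at the one concentration tested (going by the name of the read-out) and lower numbers for less inhibition:
- compound 1 `CC(C)(C)c1ccc(Oc2ccc3nc(-c4ccc(OCCCN5CCCCC5)cc4)oc3c2)cc1`: "not active" (no number reported)
- compound 2 `Fc1ccc(Oc2ccc3nc(-c4ccc(OCCCN5CCCCC5)cc4)oc3c2)cc1`: 30.3%
- compound 3 `FC(F)(F)c1ccc(Oc2ccc3nc(-c4ccc(OCCCN5CCCCC5)cc4)oc3c2)cc1`: 44.3%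

Compound 3 gives the higher of the two numbers reported; compound 2 sits below it by a number 14 percentage points higher from compound 2 to compound 3 (beyond the scatter), a modest step beyond the scatter, while compound 1 has no number at all in this assay. Compound 4 `FC(F)(F)c1cccc(Oc2ccc3nc(-c4ccc(OCCCN5CCCCC5)cc4)oc3c2)c1` differs from compound 3 only in the position of one group: 3-(trifluoromethyl)phenyl in place of 4-(trifluoromethyl)phenyl on an oxygen on an aromatic ring. Within the data shown here, no measured step moves a group around that ring, so nothing here tells how much such a shift matters. The estimate for compound 4 therefore stays close to compound 3, at 40% with a range of 22% to 56%, and the expected step of a number 4.3 percentage points lower from compound 3 to compound 4 (within the scatter) lies within the scatter.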

Compound 4, a percentage reported as inhibition, at one concentration (the size of the read-out at that concentration, not a potency): 42.7%
Compound 4: the middle estimate sits 2.7 percentage points below what was measured, within the range that was stated.
By their numbers in this assay, from the lowest: compound 2; then compounds 4 and 3 (each within the scatter of the next).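

Moving the group from 4-(trifluoromethyl)phenoxy to 3-(trifluoromethyl)phenoxy makes no clear difference in this assay (a number 1.6 percentage points lower from compound 3 to compound 4 (within the scatter)), so for this pair the inhibition does not depend on which of these two places on the ring carries the trifluoromethyl group. Both trifluoromethyl compounds read above the 4-fluorophenyl compound (a number 12.4 percentage points higher from compound 2 to compound 4 (beyond the scatter)). No independent data bear on why this shift changes so little.

Still open, on these data alone, is whether a methoxy group, a nitrile or a carboxylic acid on this ring would read like trifluoromethyl or like fluoro. Also open, as far as these compounds go, is whether fluoro, moved in the same way, would be as indifferent to the shift.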